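This account rests on a few compounds, and the source may have more. Where it says the series, first, only, none or still open, it means among the compounds named here.

Measured compounds:
compound 1 `COc1ccc(-n2cc(CN3C(=O)C[C@@H]4CC[C@@]3(C)C4(C)C)nn2)cc1` gives 330 nM in a functional assay on PANC-1 cells (Homo sapiens) for inhibition, read by MTT assay, with a stated time of 24 h; on this read-out lower numbers stand for stronger inhibition and higher numbers for weaker inhibition;
compound 2 `Cc1ccc(-n2cc(CN3C(=O)C[C@@H]4CC[C@@]3(C)C4(C)C)nn2)cc1` gives 270 nM;
compound 3 `CC1(C)[C@H]2CC[C@]1(C)N(Cc1cn(-c3ccc(C#N)cc3)nn1)C(=O)C2` gives 250 nM.

Among the compounds with values here, compound 1 has the highest of the three numbers, yet the step of a 1.2-fold lower number from compound 1 to compound 2 (0.09 log units; within the scatter) and the step of a 1.3-fold lower number from compound 1 to compound 3 (0.12 log units; within the scatter) both fall within the scatter, so no compound is set apart. Compound 4 `CC1(C)[C@H]2CC[C@]1(C)N(Cc1cn(-c3ccc(Br)cc3)nn1)C(=O)C2` differs from compound 1 by bromo in place of methoxy on an aromatic carbon. The two measured steps that also replace the methoxy on that aromatic carbon, a 1.2-fold lower number from compound 1 to compound 2 (0.09 log units; within the scatter) and a 1.3-fold lower number from compound 1 to compound 3 (0.12 log units; within the scatter), were both within the scatter, as was a 1.1-fold lower number from compound 2 to compound 3 (0.03 log units; within the scatter). A change at the same place is therefore expected to give no step beyond the scatter. Compound 4 is estimated at 280 nM, between 140 nM and 560 nM, an expected step of a 1.2-fold lower number from compound 1 to compound 4 (0.07 log units; within the scatter).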

Compound 4, half-maximal inhibitory concentration: 200 nM
Beside the measured number, compound 4's estimate is 1.4-fold (0.15 log units) above it; low and high end bracket the measured number.
By their numbers in this assay, from the lowest: compounds 4, 3, 2 and 1 (each within the scatter of the next).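

Bromo, which brings no hydrogen-bond acceptor where methoxy brings one, also leaves the number within the scatter in this assay, with a 1.7-fold lower number from compound 1 to compound 4 (0.22 log units; within the scatter). This is the largest step yet seen at this position, and the steps to the other two compounds are no different in kind: a 1.4-fold lower number from compound 2 to compound 4 (0.13 log units; within the scatter) and a 1.3-fold lower number from compound 3 to compound 4 (0.10 log units; within the scatter). So four different groups on this aromatic carbon remain indistinguishable, and nothing given here explains the result. On these data alone, whether an amine or a carboxylic acid at this place would give a step beyond the scatter stays open, as does the effect of any change to the shared core.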